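The Same Heteroaryl Swap, Tried on a Second Core

This account rests on a few compounds, and the source may have more. Where it says the series, first, only, none or still open, it means among the compounds named here.

Compound 1 `Cc1noc(C)c1-c1cnc(N)c(Oc2ccc(C(=O)Nc3cccc(Cl)n3)cc2)n1` and compound 2 `Cn1cc(-c2cnc(N)c(Oc3ccc(C(=O)Nc4cccc(Cl)n4)cc3)n2)cn1` share one core and differ in a single place: 1-methyl-1H-pyrazol-4-yl in place of 3,5-dimethyl-1,2-oxazol-4-yl on an aromatic carbon. In a functional assay on U-87MG ATCC cells for inhibition, with U-87 MG (Homo sapiens) as the target, read by MTT assay, with a stated time of 72 h (a higher number here means a weaker inhibitor, a lower number a stronger inhibitor), compound 1 gives 64100 nM. In this assay compound 2 gives 54800 nM. The step between them is a 1.2-fold lower number from compound 1 to compound 2 (0.07 log units; within the scatter), so the two values cannot be told apart.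

Compound 3 `Cc1noc(C)c1-c1cnc(N)c(NCc2ccc(C(=O)Nc3ccc(Cl)cc3)cc2)n1` carries the 3,5-dimethyl-1,2-oxazol-4-yl group on a different core; how that core differs from the core of compound 1 is not broken down here. In this assay compound 3 gives > 100000 nM, which is a limit of the assay and not a number, as noted for (the limit of > 100000 nM in this assay, at which 1 of the 3 values shown sits).

Compound 4 `Cn1cc(-c2cnc(N)c(NCc3ccc(C(=O)Nc4ccc(Cl)cc4)cc3)n2)cn1` has not been measured. It differs from compound 3 in one place: 1-methyl-1H-pyrazol-4-yl in place of 3,5-dimethyl-1,2-oxazol-4-yl on an aromatic carbon. The place is described in the same words as for the change from compound 1 to compound 2, so it is the same change, now made on the core of compound 3.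

Going by the values given here, the only guide is the earlier step, a 1.2-fold lower number from compound 1 to compound 2 (0.07 log units; within the scatter). Resting on that, the expected step is a step that the limit leaves unreadable from compound 3 to compound 4. Compound 4 is therefore expected at 120000 nM, most likely between 50000 nM and 300000 nM, and it would not be surprising if only a limit were reported again.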

Compound 4, half-maximal inhibitory concentration: > 100000 nM
Compound 4: only a limit was reported; the forecaster's own chance of this, stated with the estimate: 70%; the middle value lies beyond the limit too.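

In this assay compound 4 gives > 100000 nM, which is a limit of the assay and not a number. Compound 3 stands at a limit as well, so no step can be read between compound 3 and compound 4: the limit of > 100000 nM in this assay, at which 2 of the 4 values shown sit.

The compounds shown leave open whether 1-methyl-1H-pyrazol-4-yl in place of 3,5-dimethyl-1,2-oxazol-4-yl makes any difference on the core of compound 3.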